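Nitro to Methoxy: Expecting Compound 4

The source may hold more compounds than are shown below. What is called first, only, known or untested is meant among the compounds shown, and "the series" means these compounds.

Measured so far:
compound 1 `FC(F)(F)c1ccc2[nH]c(-c3ccccc3)nc2c1` gives 369000 nM
compound 2 `Oc1ccc(-c2nc3cc(C(F)(F)F)ccc3[nH]2)cc1` gives 219000 nM
compound 3 `O=[N+]([O-])c1ccccc1-c1nc2cc(C(F)(F)F)ccc2[nH]1` gives 3180 nM

All three numbers come from a functional assay on aorta (Rattus norvegicus, strain Wistar) for inhibition, with a stated time of 60 min; on this read-out lower numbers stand for an effect already at smaller amounts and higher numbers for an effect only at larger amounts of compound. Compound 3 has the lowest number of the three by a wide margin: compound 2 gives 219000 nM, whereas compound 3 gives 3180 nM, and compound 1 gives 369000 nM.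

Compound 4 `COc1ccccc1-c1nc2cc(C(F)(F)F)ccc2[nH]1` has not been measured. It differs from compound 3 by methoxy in place of nitro on an aromatic carbon. Within the data shown here, two measured steps bear on this. The step of a 120-fold lower number from compound 1 to compound 3 (2.06 log units; beyond the scatter) shows how much of the standing of compound 3 rests on the nitro group alone. The step of a 1.7-fold lower number from compound 1 to compound 2 (0.23 log units; within the scatter) shows that a single small oxygen-bearing group placed elsewhere on the same ring changed little. Removing the nitro should therefore cost most of that large gain, while the methoxy may give back only a small part, so a clear rise in the number is expected for compound 4, somewhere between compound 3 and compound 1. The expected step is a 25-fold higher number from compound 3 to compound 4 (1.40 log units; beyond the scatter). Compound 4 is estimated at 80000 nM, with a range from 15000 nM to 300000 nM.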

Compound 4, half-maximal effective concentration: 210000 nM
Compound 4: middle estimate off by 2.6-fold (0.42 log units), on the low side; low and high end bracket the measured number.
By their numbers in this assay, from the lowest: compound 3; then compounds 4, 2 and 1 (each within the scatter of the next).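

In this assay, putting methoxy in place of nitro at this same place on the ring gives a 66-fold higher number from compound 3 to compound 4 (1.82 log units; beyond the scatter), so the low number of compound 3 does not carry over to this other oxygen-bearing group. Methoxy in place of hydrogen gives a 1.8-fold lower number from compound 1 to compound 4 (0.24 log units; within the scatter), which means that of the three groups seen here (hydrogen, methoxy and nitro), only nitro clearly moves the number. No measurement is available to explain why nitro and methoxy differ so sharply.

The compounds shown leave open whether another group at this place, such as an amine, a nitrile or a carboxylic acid, would behave more like nitro or more like methoxy. They also leave open whether ethoxy, the next longer chain, would stay level with methoxy.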